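Acyl swap on two cores of an amide sulfonamide series

The source may hold more compounds than are shown below. What is called first, only, known or untested is meant among the compounds shown, and "the series" means these compounds.

Two cores carry the same sulfonamide–methoxy–carboxamide portion. Compound 1 `COc1c(NS(=O)(=O)c2ccc(F)cc2)cc(-c2ccc3nc(NC(=O)C4CC4)sc3n2)cc1C(N)=O` and compound 2 `COc1c(NS(=O)(=O)c2ccc(F)cc2)cc(-c2ccc3nc(NC(C)=O)sc3n2)cc1C(N)=O` share one core; in a functional assay on HCT-116 cells (Homo sapiens) for antiproliferative activity, read by MTT assay, with a stated time of 72 h (on this read-out higher numbers stand for weaker inhibition and lower numbers for stronger inhibition), compound 1 gives 2500 nM and compound 2 gives 4250 nM. The change between them, (cyclopropyl in place of methyl on a carbonyl carbon), made a 1.7-fold lower number from compound 2 to compound 1 (0.23 log units; within the scatter). Compound 3 `COc1c(NS(=O)(=O)c2ccc(F)cc2)cc(-c2ccn3nc(NC(C)=O)nc3c2)cc1C(N)=O` carries the other core, and in this assay compound 3 gives 32600 nM; the difference between the two cores is not broken down here, and the values alone show compound 3 standing highest of the three measured. Compound 4 `COc1c(NS(=O)(=O)c2ccc(F)cc2)cc(-c2ccn3nc(NC(=O)C4CC4)nc3c2)cc1C(N)=O` is the counterpart of compound 3 carrying the same change, (cyclopropyl in place of methyl on a carbonyl carbon), at the same place as before. Within the data shown here, that earlier step is the only guide. For compound 4 the expected step is a 1.7-fold lower number from compound 3 to compound 4 (0.23 log units; within the scatter), which rests on the same change having made a 1.7-fold lower number from compound 2 to compound 1 (0.23 log units; within the scatter). Compound 4 is therefore estimated at 19000 nM in this assay, most likely between 8000 nM and 45000 nM.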

Compound 4, half-maximal inhibitory concentration: > 50000 nM
Compound 4: a limit, no number; the forecaster's own chance of this, stated with the estimate: 10%; at least 2.6-fold (0.42 log units) between middle value and limit.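

In this assay compound 4 gives > 50000 nM, which is a limit of the assay and not a number: the limit of > 50000 nM in this assay, at which 1 of the 4 values shown sits. From the compounds shown here alone, with cyclopropyl in place of methyl on the carbonyl carbon, the step on this core reads an at least 1.5-fold higher number from compound 3 to compound 4 (0.18 log units; that floor lies within the scatter), so a real rise is not established, and the true size of the step stays unknown. Set beside the step on the other core, this shows neither that the change carries across unchanged nor that its outcome depends on the core: the same change on two cores in this assay, a 1.7-fold lower number (0.23 log units; within the scatter) from compound 2 to compound 1 and an at least 1.5-fold higher number (0.18 log units; that floor lies within the scatter) from compound 3 to compound 4; the limit leaves it open whether they differ.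

Going by these compounds, it remains open where compound 4 would read in this assay if it gave a number rather than a limit, which would be needed to compare the two steps. Also open, on these data alone, is whether a longer chain or an amine in place of cyclopropyl on that carbonyl carbon would give a step beyond the scatter on either core.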